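This account rests on a few compounds, and the source may have more. Where it says the series, first, only, none or still open, it means among the compounds named here.

In a functional assay on DU-145 cells (Homo sapiens) for inhibition, read by trypan blue exclusion, with a stated time of 96 h (on this read-out lower numbers stand for stronger inhibition of growth and higher numbers for weaker inhibition of growth), compound 1 (`O=C(O)c1ccc(C(=O)/C(=C\c2ccc(Cl)c([N+](=O)[O-])c2)SCc2ccc(Br)cc2)cc1`) gives 500 nM and stands lowest of the three measured numbers. Compound 2 (`CSc1ccc(/C=C(/SCc2ccc(Br)cc2)C(=O)c2ccc(C(=O)O)cc2)cc1`) gives 10000 nM and compound 3 (`CN1CCN(/C=C(/SCc2ccc(Br)cc2)C(=O)c2ccc(C(=O)O)cc2)CC1[N+](=O)[O-]`) gives 10000 nM in this assay as well. Compound 4 (`O=C(O)c1ccc(C(=O)/C(=C\c2ccc(Cl)c([N+](=O)[O-])c2)SCc2ccc(Cl)cc2Cl)cc1`) differs from compound 1 by 2,4-dichlorophenyl in place of 4-bromophenyl on a saturated chain carbon bound to a sulfur at a saturated chain carbon bound to a sulfur, and it keeps the 4-chloro-3-nitrophenyl group. The measured steps bear on this only indirectly. For the measured compounds named here, all of them replace that retained group, and no measured pair varies the 4-bromobenzyl group. Two are large (a 20-fold higher number from compound 1 to compound 2 (1.30 log units; beyond the scatter) and a 20-fold higher number from compound 1 to compound 3 (1.30 log units; beyond the scatter)) while the third stays within the scatter (no change at the digits printed from compound 2 to compound 3 (within the scatter)). They show how far the numbers can move elsewhere, but give no size or direction for this change. With no evidence for a shift, no step beyond the scatter is expected in this assay and the uncertainty stays wide. The expected step is no change at the digits printed from compound 1 to compound 4 (within the scatter) on this estimate. Compound 4 is estimated at 500 nM with a range of 150 nM to 1800 nM expected for it.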

Compound 4, concentration for 50% growth inhibition: 1000 nM
Compound 4: the middle estimate sits 2.0-fold (0.30 log units) below what was measured, within the range that was stated.
By their numbers in this assay, from the lowest: compounds 1 and 4 (each within the scatter of the next); then compounds 2 and 3 (each within the scatter of the next).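

In this assay, the first change shown at this position gives a 2.0-fold higher number from compound 1 to compound 4 (0.30 log units; within the scatter) and is the only step here that varies the group on sulfur. The exchange of 4-bromobenzyl for 2,4-dichlorobenzyl therefore stays within the scatter while the 4-chloro-3-nitrophenyl group is retained, in contrast to a 20-fold higher number from compound 1 to compound 2 (1.30 log units; beyond the scatter) when that retained group is replaced. No measured evidence accompanies this result to account for it.

Still open, going by these compounds, is whether a group of another kind on the saturated chain carbon bound to a sulfur, such as an amine, a carboxylic acid or a longer chain, would stay equally close to compound 1. Also open, on these data alone, is whether the 2,4-dichlorobenzyl group would give a similar result alongside the 4-(methylsulfanyl)phenyl group of compound 2.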